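Ring size of the benzylic amine in the sulfonamide series

This account rests on a few compounds, and the source may have more. Where it says the series, first, only, none or still open, it means among the compounds named here.

Compound 1 `CCN(CC)Cc1ccc(-c2ccnc3ccc(-c4cnc(OC)c(NS(=O)(=O)c5ccc(F)cc5F)c4)cc23)cc1`, compound 2 `CCN(Cc1ccc(-c2ccnc3ccc(-c4cnc(OC)c(NS(=O)(=O)c5ccc(F)cc5F)c4)cc23)cc1)C1CCCCC1` and compound 3 `COc1ncc(-c2ccc3nccc(-c4ccc(CN5CCCC5)cc4)c3c2)cc1NS(=O)(=O)c1ccc(F)cc1F` share one core and differ only in the amine carried on a saturated chain carbon bound to an aromatic carbon. In a functional assay on A549 cells (Homo sapiens) for cytotoxicity, read by MTT assay, with a stated time of 72 h (a higher number here means a weaker inhibitor, a lower number a stronger inhibitor), compound 1 gives 22 nM, compound 2 gives 20.2 nM and compound 3 gives 37.5 nM. Compound 3 carries the highest of the three numbers, yet a 1.7-fold higher number from compound 1 to compound 3 (0.23 log units; within the scatter) and a 1.9-fold higher number from compound 2 to compound 3 (0.27 log units; within the scatter), so the three cannot be separated. Likewise a 1.1-fold lower number from compound 1 to compound 2 (0.04 log units; within the scatter).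

Compound 4 `COc1ncc(-c2ccc3nccc(-c4ccc(CN5CCCCC5)cc4)c3c2)cc1NS(=O)(=O)c1ccc(F)cc1F` is not yet measured. Its change from compound 3 is piperidin-1-yl in place of pyrrolidin-1-yl on a saturated chain carbon bound to an aromatic carbon. Every measured step in the series touches this same amine, and each of them (a 1.1-fold lower number from compound 1 to compound 2 (0.04 log units; within the scatter), a 1.7-fold higher number from compound 1 to compound 3 (0.23 log units; within the scatter), a 1.9-fold higher number from compound 2 to compound 3 (0.27 log units; within the scatter)) stays within the scatter. On that basis no step beyond the scatter is expected in this assay for compound 4, in either direction, so a 1.1-fold lower number from compound 3 to compound 4 (0.03 log units; within the scatter) is the expected outcome. Compound 4 is estimated at 35 nM, with a range from 15 nM to 80 nM.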

Compound 4, half-maximal inhibitory concentration: 15.5 nM
Beside the measured number, compound 4's estimate is 2.3-fold (0.35 log units) above it; low and high end bracket the measured number.
By their numbers in this assay, from the lowest: compounds 4, 2, 1 and 3 (each within the scatter of the next, the first and the last beyond it).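

In this assay, the step of a 2.4-fold lower number from compound 3 to compound 4 (0.38 log units; beyond the scatter) is the only one in the series that lies beyond the scatter, so the amine on the saturated chain carbon bound to an aromatic carbon is not wholly indifferent to change: the six-membered ring and the five-membered ring can be told apart here. Within the data shown here, the piperidin-1-yl group does not separate from the open-chain amines, since a 1.3-fold lower number from compound 2 to compound 4 (0.12 log units; within the scatter) and a 1.4-fold lower number from compound 1 to compound 4 (0.15 log units; within the scatter) both stay within the scatter, which leaves compound 3 and compound 4 as the one pair that parts. Nothing at hand bears on why the two rings differ.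

As far as these compounds go, whether a seven-membered azepan-1-yl ring would extend the step remains open. So does the effect of a second ring hetero atom at this place, as in morpholin-4-yl or piperazin-1-yl.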